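Shortening the chain on the double-bonded nitrogen

The source may hold more compounds than are shown below. What is called first, only, known or untested is meant among the compounds shown, and "the series" means these compounds.

Compound 3 `CCCCCC/N=C(\C)c1c(O)c2ccccc2oc1=O` gives the lowest number of the three measured compounds in an assay on isolated protein for inhibition of myosin-2 (Bos taurus), read by spectrophotometry, with a stated time of 24 min (on this read-out lower numbers stand for stronger inhibition and higher numbers for weaker inhibition), at 2900 nM. Compound 1 `C/C(=N\CC(C)C)c1c(O)c2ccccc2oc1=O` gives 34000 nM in this assay, and compound 2 `C/C(=N\CCO)c1c(O)c2ccccc2oc1=O` gives 92000 nM. The separation is a 12-fold lower number from compound 1 to compound 3 (1.07 log units; beyond the scatter) and a 32-fold lower number from compound 2 to compound 3 (1.50 log units; beyond the scatter), both beyond the scatter.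

Compound 4 `CCC(C)/N=C(\C)c1c(O)c2ccccc2oc1=O` carries sec-butyl in place of hexyl on a double-bonded nitrogen, so the substituent on that nitrogen becomes shorter and branched. The measured step that bears most directly on this is the one in which a 12-fold lower number from compound 1 to compound 3 (1.07 log units; beyond the scatter) accompanied a longer chain; compound 4 goes back toward a group of the size found in compound 1, though with a different branching. The step of a 2.7-fold higher number from compound 1 to compound 2 (0.43 log units; beyond the scatter) concerns a hydroxy group and is not informative here. A higher number is therefore expected for compound 4 in this assay, of a size approaching the step from compound 1 to compound 3 but possibly smaller, since the branched sec-butyl is not the same group as in compound 1. The expected step is a 6.9-fold higher number from compound 3 to compound 4 (0.84 log units; beyond the scatter). Compound 4 is estimated at 20000 nM, with a range from 6000 nM to 60000 nM.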

Compound 4, half-maximal inhibitory concentration: >= 100000 nM
Compound 4 was reported as a limit; the forecaster's own chance of this, stated with the estimate: 5%; middle value at least 5.0-fold (0.69 log units) away from the limit.
By their numbers in this assay, from the lowest: compound 3; then compound 1; then compound 2. At a limit, above all of these: compound 4.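

Compound 4 is reported only as a limit in this assay, not as a number: the limit of >= 100000 nM in this assay, at which 1 of the 4 values shown sits. Even so, sec-butyl in place of hexyl gives an at least 34-fold higher number from compound 3 to compound 4 (1.53 log units; beyond the scatter), sec-butyl in place of isobutyl gives an at least 2.9-fold higher number from compound 1 to compound 4 (0.46 log units; beyond the scatter), and sec-butyl in place of 2-hydroxyethyl gives an at least 1.0-fold higher number from compound 2 to compound 4 (0.03 log units; that floor lies within the scatter). The earlier compounds shown here tied this position to hexyl, isobutyl and 2-hydroxyethyl only; compound 4 adds that a hydroxy group is not needed for a weak result, and that exchanging one branched group on the double-bonded nitrogen for another can by itself carry the number beyond the scatter.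

From the compounds shown here alone, the last of these steps cannot be read, so the order of compound 2 and compound 4 stays unknown, and how far compound 4 lies from any other compound is known only as a floor. Open as well is whether straight-chain butyl, a chain longer than hexyl, or a cyclohexyl group would follow hexyl or sec-butyl, so length and branching remain unseparated in this series.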